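This account rests on a few compounds, and the source may have more. Where it says the series, first, only, none or still open, it means among the compounds named here.

Among the compounds with values here, compound 1, `CCCCCCCCCCCC(=O)OC[C@H](CSC[C@@H](N)C(=O)NC(C)(C)CO)OC(=O)CCCCCCCCCCC`, gives 15500 nM in an assay on HEK293 cells for agonist activity at Toll-like receptor 2 (Homo sapiens) (a higher number here means that more compound is needed for the effect, a lower number that less compound is needed), the higher of the two numbers recorded, with compound 2 the only neighbour. Compound 2, `CCCCCCCCCCCC(=O)OC[C@H](CSC[C@@H](N)C(=O)N[C@@H](C)CO)OC(=O)CCCCCCCCCCC`, gives 1560 nM in this assay. Within the data shown here, the one measured step goes a 9.9-fold lower number from compound 1 to compound 2 (1.00 log units; beyond the scatter), when 1-(hydroxymethyl)ethyl replaces 1-(hydroxymethyl)-1-methylethyl on the amide-type nitrogen.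

Compound 3, `CCCCCCCCCCCC(=O)OC[C@H](CSC[C@@H](N)C(=O)N[C@@H](CC)COCC(=O)O)OC(=O)CCCCCCCCCCC`, differs from compound 1 at the same nitrogen: 1-((carboxymethoxy)methyl)propyl in place of 1-(hydroxymethyl)-1-methylethyl on an amide-type nitrogen. Two parts of this change can be told apart. The loss of a methyl at the carbon attached to the nitrogen, leaving one alkyl group there, matches what the step from compound 1 to compound 2 did, and that step was beyond the scatter. The extension of the hydroxymethyl into a carboxymethoxymethyl group, and the change of methyl to ethyl, have no measured counterpart among these compounds, so their effect is unknown. She therefore expects a step of a 4.4-fold lower number from compound 1 to compound 3 (0.65 log units; beyond the scatter), a lower number, smaller than the step to compound 2 to allow for the uncovered parts. Compound 3 is estimated at 3500 nM in this assay, within 800 nM to 15000 nM.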

Compound 3, half-maximal effective concentration: 6500 nM
Beside the measured number, compound 3's estimate is 1.9-fold (0.27 log units) below it; low and high end bracket the measured number.
By their numbers in this assay, from the lowest: compound 2; then compound 3; then compound 1.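

The larger group on the amide-type nitrogen, 1-((carboxymethoxy)methyl)propyl with 9 heavy atoms against 5 for the group that leaves, still gives a 2.4-fold lower number from compound 1 to compound 3 (0.38 log units; beyond the scatter) in this assay, so the position accepts a clearly longer substituent ending in a carboxylic acid without a rise above compound 1. Set against the smaller 1-(hydroxymethyl)ethyl group, however, the same substituent gives a 4.2-fold higher number from compound 2 to compound 3 (0.62 log units; beyond the scatter), which places compound 3 between the other two compounds and shows that the lower number of compound 2 is not fully kept. Nothing at hand explains either step.

The change to compound 3 alters the methyl and the hydroxymethyl arm together, so the compounds shown cannot separate the contribution of the ethyl group from that of the carboxymethoxy extension; a 1-(hydroxymethyl)propyl group would speak to the first of these. From the compounds shown here alone, it also remains open whether an amine or a simple ester in place of the terminal carboxylic acid, or a longer chain between that acid and the ether oxygen, would move the number further in either direction.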